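Compound 3 to compound 4: chloro in place of fluoro

The source may report more compounds than this note shows. Statements on the series, on what has been measured and on what is new or still open speak of the compounds shown alone.

Measured values (a functional assay on MCF7 cells (Homo sapiens) for cytotoxicity, read by MTT assay, with a stated time of 96 h; a lower number here means a stronger inhibitor, a higher number a weaker inhibitor)
compound 1 `COc1cc(C(=O)c2cn(-c3ccccc3)cc2-c2ccccc2Cl)cc(OC)c1OC` gives 76 nM
compound 2 `COc1cccc(-c2cn(-c3ccccc3)cc2C(=O)c2cc(OC)c(OC)c(OC)c2)c1` gives 180 nM
compound 3 `COc1cc(C(=O)c2cn(-c3cccc(C)c3)cc2-c2ccccc2F)cc(OC)c1OC` gives 190 nM

In this assay compound 3 (190 nM) lies within the scatter of compound 2 (180 nM), and both numbers are higher than that of compound 1 (76 nM). Compound 4 `COc1cc(C(=O)c2cn(-c3cccc(C)c3)cc2-c2ccccc2Cl)cc(OC)c1OC` has chloro in place of fluoro on an aromatic carbon, ortho to a large group (chloro in place of fluoro on an aromatic carbon). Among the measured compounds shown here, the one measured step at this group (a 2.4-fold higher number from compound 1 to compound 2 (0.37 log units; beyond the scatter)) puts 3-methoxyphenyl in place of 2-chlorophenyl, so it shows that the group can matter but does not compare fluoro with chloro. For the measured compounds named here, no direct pair for that exchange has been measured. Compound 1 (76 nM) carries the same 2-chlorophenyl as compound 4 but also differs from it elsewhere, so it supports a lower number only loosely. A small move toward a lower number is expected, not beyond the scatter (a 1.7-fold lower number from compound 3 to compound 4 (0.24 log units; within the scatter)). Compound 4 is estimated at 110 nM (expected range 50 nM to 240 nM).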

Compound 4, half-maximal inhibitory concentration: 420 nM
Compound 4: the middle estimate sits 3.8-fold (0.58 log units) below what was measured; measured number outside the range, above it.
By their numbers in this assay, from the lowest: compound 1; then compounds 2 and 3 (each within the scatter of the next); then compound 4.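

In this assay, among the compounds shown here, the first direct comparison at this position (a 2.2-fold higher number from compound 3 to compound 4 (0.34 log units; beyond the scatter)) shows that the number is sensitive to a single-atom exchange, with chloro in place of fluoro moving it upward when the methyl is present. The 2-chlorophenyl group does not by itself secure a low number: methyl in place of hydrogen on an aromatic carbon, with 2-chlorophenyl held constant, gives a 5.5-fold higher number from compound 1 to compound 4 (0.74 log units; beyond the scatter). No supporting measurement accounts for either step.

As far as these compounds go, each exchange has been read in only one setting, so it remains open whether chloro in place of fluoro gives the same direction without the methyl, and whether the methyl step holds with fluoro. From the compounds shown here alone, how a bromo, hydroxy or amine at this position would compare also remains open.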